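The source may report more compounds than this note shows. Statements on the series, on what has been measured and on what is new or still open speak of the compounds shown alone.

Measured so far in a functional assay on RD cells (Homo sapiens) for inhibition, read by luminescence and ATP content, with a stated time of 72 h; a lower number here means that less compound is tolerated, a higher number that more compound is tolerated:
- Compound 1 `CCCCc1ccc(-c2ccc3ncc(C(=O)OCC)cc3c2)cc1`: > 7400 nM, a limit
- Compound 2 `CC(C)c1nc(-c2cnc3ccc(-c4ccc(N)cc4)cc3c2)no1`: > 800 nM, a limit
- Compound 3 `CCCCc1ccc(-c2ccc3ncc(-c4noc(C(F)(F)F)n4)cc3c2)cc1`: > 7400 nM, a limit

Compound 3 gives > 7400 nM, which is a limit and not a number. No value in this assay is more than a limit so far, with the limit of > 7400 nM in this assay, at which 2 of the 3 values shown sit, and with the limit of > 800 nM in this assay, at which 1 of the 3 values shown sits.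

Compound 4 `CC(C)c1ccc(-c2ccc3ncc(-c4noc(C(F)(F)F)n4)cc3c2)cc1` comes from compound 3 by a single change: isopropyl in place of butyl on an aromatic carbon. The change lies para to a large group. Going by the values given here, the only measured step, a step that the two limits leave unreadable from compound 1 to compound 3, concerns a different group, so no measured step bears on this change or gives it a size.

The expectation rests on compound 3 alone, whose limit is > 7400 nM. No step beyond the usual scatter is expected in this assay, in either direction. The expected step is a step that the limit leaves unreadable from compound 3 to compound 4. Compound 4 is estimated at 9000 nM, with an expected range from 3000 nM to 30000 nM, and it may well be reported only as a limit.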

Compound 4, half-maximal cytotoxic concentration: > 200000 nM
Compound 4 was reported as a limit; the forecaster's own chance of this, stated with the estimate: 75%; middle value at least 22-fold (1.34 log units) from the limit.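

In this assay compound 4 gives > 200000 nM, which is a limit. Compound 3 also stands only at a limit, and the step between compound 3 and compound 4 cannot be read. The compounds shown leave open whether isopropyl in place of butyl changes the tolerated concentration at all.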